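The compounds below may be only part of what the source reports. "The series", "measured", "known", "first", "only" and "open" are said of these compounds alone.

In a functional assay on A549 cells (Homo sapiens) for cytotoxicity, read by MTT assay, with a stated time of 24 h (on this read-out higher numbers stand for weaker inhibition and lower numbers for stronger inhibition), compound 1 `O=Cc1cc2ccccc2n(Cc2ccccc2)c1=O` reports only a limit of the assay, > 100000 nM. Among the compounds with values here, compound 2 `C#CCn1c(=O)c(/C=C/C(=O)/C=C(O)/C=C/c2ccc(O)c(OC)c2)cc2cc(OC)ccc21` gives 20600 nM, and this is the only actual number available in this assay, so it is the sole anchor for anything that follows. Compound 3 `C#CCn1c(=O)c(/C=C/C(=O)/C=C(O)/C=C/c2ccc(O)c(OC)c2)cc2cc(F)ccc21` has not yet been measured. It departs from compound 2 at a single place: fluoro in place of methoxy on an aromatic carbon. The rest of the structure stays the same. Within the data shown here, no measured pair shows what such an exchange does in this assay, so the size of the step cannot be read from data. The expectation therefore stays close to compound 2 at 20600 nM, with no firm direction and at most a slight lean toward stronger inhibition. The expected change is small, a 1.2-fold lower number from compound 2 to compound 3 (0.08 log units; within the scatter), and is not expected to clearly exceed the usual scatter. For compound 3 the estimate is 17000 nM, with an expected range from 7000 nM to 42000 nM.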

Compound 3, half-maximal inhibitory concentration: 40500 nM
The estimate for compound 3 lay 2.4-fold (0.38 log units) below the measured number, and the stated range covers the measured number.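

In this assay, within the data shown here, the exchange of methoxy for fluoro, on an aromatic carbon meta to a fused ring and para to a fused ring, provides the only step that can be read so far: a 2.0-fold higher number from compound 2 to compound 3 (0.29 log units; within the scatter). The earlier compounds shown here could not show what happens at this position, and this pair shows that removing the methoxy group, with its hydrogen-bond acceptor, and placing the single fluorine atom there gives no step beyond the scatter, so compound 2 and compound 3 cannot be told apart on this read-out. Nothing measured here bears on why the exchange reads this way.

The compounds shown leave open whether any other group on this aromatic carbon, such as chloro, an amine, a carboxylic acid or a longer chain like ethoxy, would give a step that clearly exceeds the scatter. Also open, going by these compounds, is whether fluoro in place of methoxy would give a step of similar size on another aromatic carbon of the shared core, as this single pair speaks for one position only.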